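A Fluorine on the Benzyl Group: Expected Cell Viability

The compounds below may be only part of what the source reports. "The series", "measured", "known", "first", "only" and "open" are said of these compounds alone.

Compound 1 `O=C1COCCN1c1ccc(/N=C\c2c[nH]c3ccccc23)cc1` gives 105% in an ADME assay on BV-2 cells (Mus musculus) for cytotoxicity, read by MTT assay, with a stated time of 48 h, tested at 40 uM; on this read-out lower numbers stand for a stronger effect and higher numbers for a weaker effect at the one concentration tested. For the measured compounds named here, compound 2 `O=C1COCCN1c1ccc(/N=C\c2cn(Cc3ccccc3)c3ccccc23)cc1` gives 69.5% in this assay, the lowest of the two numbers so far; this followed a number 35.5 percentage points lower from compound 1 to compound 2 (beyond the scatter) when benzyl replaced hydrogen on the aromatic nitrogen. Compound 3 `O=C1COCCN1c1ccc(/N=C\c2cn(Cc3ccc(F)cc3)c3ccccc23)cc1` differs from compound 2 by fluoro in place of hydrogen on an aromatic carbon. Going by the values given here, no measured step covers this small change, and the one known step concerns a different place, so no shift beyond the scatter is expected. Compound 3 is therefore estimated at 65% in this assay, with a likely range from 45% to 88%, which is expected to mean a number 4.5 percentage points lower from compound 2 to compound 3 (within the scatter).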

Compound 3, a percentage reported as activity, at one concentration (the size of the read-out at that concentration, not a potency): 77.7%
For compound 3 the middle estimate is 12.7 percentage points below the measured one, and the stated range covers the measured number.
By their numbers in this assay, from the lowest: compounds 2 and 3 (each within the scatter of the next); then compound 1.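

In this assay, 4-fluorobenzyl in place of benzyl gives a number 8.2 percentage points higher from compound 2 to compound 3 (within the scatter), so this single fluoro, on an aromatic carbon para to a large group, does not separate compound 3 from compound 2. Replacing the hydrogen on the aromatic nitrogen with 4-fluorobenzyl still gives a number 27.3 percentage points lower from compound 1 to compound 3 (beyond the scatter), so the fall seen with benzyl is kept when the fluoro is present. Nothing available explains these numbers. Still open, going by these compounds, is how a chloro, methoxy or amine group at this same place would read, and whether any of them would move the number beyond the scatter.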